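The source may hold more compounds than are shown below. What is called first, only, known or untested is meant among the compounds shown, and "the series" means these compounds.

In a functional assay on HEL cells (Homo sapiens) for cytotoxicity (on this read-out lower numbers stand for higher toxicity in this test and higher numbers for lower toxicity in this test), compound 1 `CCCCCCCc1cc2cn([C@H]3C[C@H](O)[C@@H](CO)O3)c(=O)nc2o1` gives > 50000 nM as a limit of the assay. Compound 2 `CCCCCCCCc1cc2cn([C@H]3C[C@H](O)[C@@H](CO)O3)c(=O)nc2o1` gives > 50000 nM as a limit too and so has no number of its own. Within the data shown here, the only measured step is a step that the two limits leave unreadable from compound 1 to compound 2 and it gives no size, with the limit of > 50000 nM in this assay, at which 2 of the 2 values shown sit, holding for both compounds. Compound 3 `C#CCCCCc1cc2cn([C@H]3C[C@H](O)[C@@H](CO)O3)c(=O)nc2o1` carries ethynyl in place of butyl on a saturated chain carbon, four bonds along the chain from an aromatic carbon, counted as ethynyl in place of butyl on a saturated chain carbon, four bonds along the chain from an aromatic carbon for this change. With no size to carry over, no step beyond the scatter is expected, and the estimated step is a number no higher from compound 2 to compound 3 (the limit leaves the size open) in this assay for now. For compound 3 the estimate is 50000 nM and the expected range runs from 20000 nM to 100000 nM in this series.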

Compound 3, half-maximal cytotoxic concentration: > 200000 nM
Compound 3 ended at the assay's limit; the forecaster's own chance of this, stated with the estimate: 85%; middle value at least 4.0-fold (0.60 log units) away from the limit.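

In this assay compound 3 gives > 200000 nM, a limit of the assay. Among these compounds, compound 1 and compound 2 also stand at limits, so no step among the three can be read. Open remains whether ethynyl in place of butyl changes the half-maximal cytotoxic concentration at all.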